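Shortening the Alkyl Chain on a Diaryl Urea

The compounds below may be only part of what the source reports. "The series", "measured", "known", "first", "only" and "open" are said of these compounds alone.

Among the three compounds measured in an assay on isolated protein for inhibition of acyl-CoA:cholesterol acyltransferase (Oryctolagus cuniculus) (a lower number here means a stronger inhibitor, a higher number a weaker inhibitor), compound 1 `CCCCCCCCCCCCCCc1ccc(NC(=O)Nc2c(C(C)C)cccc2C(C)C)cc1` stands highest: compound 1 gives 500 nM. Compound 2 `CCCCCCCCc1ccc(NC(=O)Nc2c(C(C)C)cccc2C(C)C)cc1` gives 11 nM in this assay, and compound 3 `CCCCc1ccc(NC(=O)Nc2c(C(C)C)cccc2C(C)C)cc1` gives 29 nM. Both measured steps that start from compound 1 remove part of the long chain and lower the number sharply: a 45-fold lower number from compound 1 to compound 2 (1.66 log units; beyond the scatter) and a 17-fold lower number from compound 1 to compound 3 (1.24 log units; beyond the scatter). Between the two shorter chains the step is smaller, a 2.6-fold higher number from compound 2 to compound 3 (0.42 log units; beyond the scatter).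

Compound 4 `CCCCCCCCCc1ccc(NC(=O)Nc2c(C(C)C)cccc2C(C)C)cc1` differs from compound 1 by hydrogen in place of pentyl on a saturated chain carbon, nine bonds along the chain from an aromatic carbon. This removes less of the chain than either measured step from compound 1, yet the chain that remains lies close in length to that of compound 2, whose value of 11 nM is the lowest of the three. A large decrease from compound 1 is therefore expected, though it may fall somewhat short of the step to compound 2. Compound 4 is expected to give 20 nM in this assay, with a range of 8 nM to 60 nM, which means an expected step of a 25-fold lower number from compound 1 to compound 4 (1.40 log units; beyond the scatter).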

Compound 4, half-maximal inhibitory concentration: 9 nM
For compound 4 the middle estimate is 2.2-fold (0.35 log units) above the measured one; the range from low to high includes it.
By their numbers in this assay, from the lowest: compounds 4 and 2 (each within the scatter of the next); then compound 3; then compound 1.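

For the compounds shown here, removing only the pentyl at the saturated chain carbon, nine bonds along the chain from an aromatic carbon, gives a 56-fold lower number from compound 1 to compound 4 (1.74 log units; beyond the scatter), so a large step does not require cutting the chain as far back as the earlier steps from compound 1 did. Near the shorter end of the series, methyl in place of hydrogen at eight bonds along the chain gives a 1.2-fold lower number from compound 2 to compound 4 (0.09 log units; within the scatter), so this assay does not separate these two chains, whereas pentyl in place of hydrogen at four bonds along the chain gives a 3.2-fold lower number from compound 3 to compound 4 (0.51 log units; beyond the scatter). Nothing shown here explains why the number changes with chain length.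

On these data alone, it remains open whether a decyl or dodecyl chain on the shared core would lie nearer compound 4 or compound 1, and where between those chains the number begins to rise. As far as these compounds go, what an amine or a carboxylic acid at the end of the chain would do also remains open.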